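Swapping Thiazole for Isopropyl: What Solubility to Expect

A few compounds are considered here, and "the series" means these few. Any claim that something is new, unique, unknown or untested is made for them only; others in the source may bear on it.

Of the compounds shown here, three built on one shared core have been tested in a physicochemical assay for solubility; on this read-out higher numbers stand for higher solubility and lower numbers for lower solubility. Compound 1 `COc1ccccc1C(=O)NC(=O)Nc1ccc(-c2ccccc2)c(C(C)C)c1` returns only a limit, < 1 ug/mL. Compound 2 `COc1ccccc1C(=O)NC(=S)Nc1ccc(N2CCCCC2)c(Cl)c1` also returns a limit, < 1 ug/mL. Among the measured compounds shown here, compound 3 `COc1ccccc1C(=O)NC(=O)Nc1ccc(-c2nccs2)c(C(F)(F)F)c1` is the only one to give a number, 1.1 ug/mL, so it stands at the top of the small range seen, while the other two rest at the limit of < 1 ug/mL in this assay, at which 2 of the 3 values shown sit. Compound 4 `COc1ccccc1C(=O)NC(=O)Nc1ccc(C(C)C)c(C(F)(F)F)c1` differs from compound 3 in one place: isopropyl in place of 1,3-thiazol-2-yl on an aromatic carbon. For the measured compounds named here, no measured pair shares this change, so its size is unknown. Compound 1 also carries an isopropyl and gives only a limit, < 1 ug/mL, which points to no gain. Compound 4 is expected to shift by a 1.4-fold lower number from compound 3 to compound 4 (0.14 log units; within the scatter) in this assay, landing near 0.8 ug/mL, within 0.3 ug/mL to 2.5 ug/mL.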

Compound 4, solubility: < 1 ug/mL
Compound 4: no number, only a limit; the forecaster's own chance of this, stated with the estimate: 55%; the middle value is on the limit's open side.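

Putting isopropyl in place of 1,3-thiazol-2-yl on this aromatic carbon, ortho to a trifluoromethyl group, gives in this assay an at least 1.1-fold lower number from compound 3 to compound 4 (0.04 log units; that floor lies within the scatter). Compound 4 returns a limit rather than a number, so only the floor of this step is known, and a real loss is not established. What is new is that this single change brings no reading clear of the limit: the limit of < 1 ug/mL in this assay, at which 3 of the 4 values shown sit.

On these data alone, whether an amine or a carboxylic acid at this position would give a measurable number remains open. So does the true size of this step.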